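Series notes: from compound 3 toward compound 4

This account rests on a few compounds, and the source may have more. Where it says the series, first, only, none or still open, it means among the compounds named here.

Measured so far:
- compound 1, `CC(=O)N1N=C(c2ccccc2)CC1c1cccc(Cl)c1Cl`, 31600 nM
- compound 2, `CC(=O)N1N=C(c2ccco2)CC1c1ccc([N+](=O)[O-])cc1`, 21300 nM
- compound 3, `O=CCN1N=C(c2ccc3ccccc3c2)CC1c1ccccc1`, 7400 nM

Three compounds carry numbers in a functional assay on PC-3 cells (Homo sapiens) for cytotoxicity, read by sulforhodamine B assay, with a stated time of 48 h; a higher number here means a weaker inhibitor, a lower number a stronger inhibitor. Compound 3 has the lowest of the three; compound 2 sits at a number beyond the scatter above it, and compound 1 further still, also beyond the scatter. Within the data shown here, none of these three differ from one another in a single place, so no direct step between measured compounds is available.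

Compound 4, `O=CCN1N=C(c2ccc3ccccc3c2)CC1c1cccc([N+](=O)[O-])c1`, is the next one to be measured. It differs from compound 3 in one place: nitro in place of hydrogen on an aromatic carbon. Compound 2 also carries a nitro group, but it differs from compound 3 in several places at once, so its value says nothing direct about this change.

Among the measured compounds shown here, with no step of this kind on hand, the expectation is for a step from compound 3 to compound 4 that stays within the scatter, in no settled direction, that is a 1.1-fold lower number from compound 3 to compound 4 (0.02 log units; within the scatter). Compound 4 is therefore estimated at 7000 nM, with a range from 2500 nM to 20000 nM.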

Compound 4, half-maximal inhibitory concentration: 2980 nM
Compound 4: middle estimate off by 2.3-fold (0.37 log units), on the high side, and the stated range covers the measured number.
By their numbers in this assay, from the lowest: compound 4; then compound 3; then compounds 2 and 1 (each within the scatter of the next).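

In this assay the change from phenyl to 3-nitrophenyl brings a 2.5-fold lower number from compound 3 to compound 4 (0.40 log units; beyond the scatter) and gives the series its first reading of a single change. The step is modest, but it shows that this aromatic carbon, meta to a large group, can carry nitro without a loss in this assay, and that the number responds to substitution at this place. Compound 2 also carries nitro, but it differs from compound 3 in several places and cannot show this.

Going by these compounds, whether the lower number is specific to nitro remains open, as an amine, a nitrile or a methoxy group on the same carbon would test that. Also open, on these data alone, is whether the same change would give a similar step on the core of compound 1. No measurement at hand accounts for the step.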